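Nitrooxy onto the Benzoate Methyl: Expected Plasma Half-Life

The compounds below may be only part of what the source reports. "The series", "measured", "known", "first", "only" and "open" are said of these compounds alone.

Compound 1 `CC(=O)Oc1ccccc1C(=O)O[C@H]1CO[C@H]2[C@@H]1OC[C@H]2O`: 0.055 h
Compound 2 `CC(=O)Oc1ccccc1C(=O)O[C@H]1CO[C@H]2[C@@H]1OC[C@H]2OC(=O)c1ccc(C)cc1`: 0.105 h
Compound 3 `CC(=O)Oc1ccccc1C(=O)O[C@H]1CO[C@H]2[C@@H]1OC[C@H]2OC(=O)c1ccccc1CO[N+](=O)[O-]`: 0.045 h

These numbers come from an ADME assay on a cell-free system (plasma, Homo sapiens) for metabolic stability, with Plasma (Rattus norvegicus) as the target, read by HPLC, at pH 7.4; a higher number here means that the compound lasts longer, a lower number that the compound disappears faster. Compound 2 gives the highest of the three, though the step of a 1.9-fold higher number from compound 1 to compound 2 (0.28 log units; within the scatter) stays within the scatter, while the step of a 2.3-fold lower number from compound 2 to compound 3 (0.37 log units; beyond the scatter) is a modest lowering beyond it.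

Compound 4 `CC(=O)Oc1ccccc1C(=O)O[C@H]1CO[C@H]2[C@@H]1OC[C@H]2OC(=O)c1ccc(CO[N+](=O)[O-])cc1` differs from compound 2 in one place: nitrooxy in place of hydrogen on a saturated chain carbon bound to an aromatic carbon. For the measured compounds named here, the only measured step that bears on this is the one from compound 2 to compound 3, which also turns a methyl into a (nitrooxy)methyl and lowered the half-life modestly. A similar modest lowering is therefore expected for compound 4, a step of a 2.1-fold lower number from compound 2 to compound 4 (0.32 log units; beyond the scatter). Compound 4 is estimated to give 0.05 h in this assay, expected between 0.025 h and 0.1 h.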

Compound 4, half-life: 0.1 h
For compound 4 the middle estimate is 2.0-fold (0.30 log units) below the measured one; the range from low to high includes it.
By their numbers in this assay, from the lowest: compounds 3, 1, 4 and 2 (each within the scatter of the next, the first and the last beyond it).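

In this assay, placing nitrooxy on the methyl of the 4-methylphenyl group changes little, with a 1.1-fold lower number from compound 2 to compound 4 (0.02 log units; within the scatter). The lowering seen with compound 3 therefore does not follow the (nitrooxy)methyl group wherever it sits on the ring: 4-((nitrooxy)methyl)phenyl in place of 2-((nitrooxy)methyl)phenyl gives a 2.2-fold higher number from compound 3 to compound 4 (0.35 log units; beyond the scatter). No available data explain this difference between the two placements.

Still open, on these data alone, is whether a longer chain ending in nitrooxy would keep the half-life of compound 4. Also open, as far as these compounds go, is how a carboxylic acid on that ring would behave.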